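Anilide series: dropping the trifluoromethyl from the chloroanilide

This account rests on a few compounds, and the source may have more. Where it says the series, first, only, none or still open, it means among the compounds named here.

Compound 1 `COc1ccc2nc(C)cc(OCC(=O)Nc3cc(C)ccc3C)c2c1` and compound 2 `COc1ccc2nc(C)cc(OCC(=O)Nc3ccc(Cl)c(C(F)(F)F)c3)c2c1` share one core and differ only in the anilide. In a toxicity assay on HepG2 cells (Homo sapiens) for inhibition, read by CellTiter-Glo, with a stated time of 48 h (a higher number here means a weaker inhibitor, a lower number a stronger inhibitor), compound 1 gives only a limit of the assay, > 100000 nM. In this assay compound 2 gives 79400 nM. Within the data shown here, compound 2 stands as the only compound with an actual number; the remaining value is a limit (the limit of > 100000 nM in this assay, at which 1 of the 2 values shown sits). Compound 3 `COc1ccc2nc(C)cc(OCC(=O)Nc3ccc(Cl)cc3)c2c1` is not yet measured and differs from compound 2 by hydrogen in place of trifluoromethyl on an aromatic carbon. Among the measured compounds shown here, with no measured step of this kind to lean on, the step of a 1.5-fold higher number from compound 2 to compound 3 (0.18 log units; within the scatter) in this assay is expected to be small, within the scatter or slightly toward weaker inhibition. Compound 3 is estimated at 120000 nM, between 50000 nM and 300000 nM, and may well return as a limit.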

Compound 3, half-maximal inhibitory concentration: > 100000 nM
Compound 3: a limit, no number; the forecaster's own chance of this, stated with the estimate: 55%; the middle value does not contradict the limit.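

In this assay, hydrogen in place of trifluoromethyl, on the aromatic carbon ortho to the chloro group, gives an at least 1.2-fold higher number from compound 2 to compound 3 (0.10 log units; that floor lies within the scatter). This position therefore yields only a floor for the change, with no measured size, and the step between the two limit compounds, compound 1 and compound 3, cannot be read. Compound 2 remains the only compound in the series with an actual number: the limit of > 100000 nM in this assay, at which 2 of the 3 values shown sit.

Open, from the compounds shown here alone, is how far the step from trifluoromethyl to hydrogen really reaches. Also open, going by these compounds, is whether a nitrile, an amine or a carboxylic acid at this position would give a number rather than a limit.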